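A few compounds are considered here, and "the series" means these few. Any claim that something is new, unique, unknown or untested is made for them only; others in the source may bear on it.

Four close relatives are compared in a functional assay on MT4 cells (Homo sapiens) for cytotoxicity; a higher number here means a weaker inhibitor, a lower number a stronger inhibitor. Compound 1 `Cc1ccccc1[S+]([O-])c1cccc(N)c1C#N` and compound 2 `N#Cc1c(N)cccc1[S+]([O-])c1ccccc1Br` share one core, while compound 3 `Cc1ccccc1S(=O)(=O)c1cccc(N)c1C#N` and compound 4 `N#Cc1c(N)cccc1S(=O)(=O)c1ccccc1Br` share another; how the core of compound 3 differs from the core of compound 1 is not broken down here. In this assay compound 1 gives only a limit, > 200000 nM. Compound 2 gives 168000 nM in this assay. The change between them is bromo in place of methyl on an aromatic carbon and it made a step of an at least 1.1-fold lower number from compound 1 to compound 2 (0.07 log units; that floor lies within the scatter). Compound 3 also gives only a limit in this assay, > 200000 nM. The picture so far is dominated by the limit of > 200000 nM in this assay, at which 2 of the 3 values shown sit, so most of what is seen is the edge of the assay rather than a clear difference between compounds. The change from compound 3 to compound 4 is the same change, (bromo in place of methyl on an aromatic carbon), made on the other core. Because the earlier step of an at least 1.1-fold lower number from compound 1 to compound 2 (0.07 log units; that floor lies within the scatter) stayed within the scatter, a step of similar size is expected here, an at least 1.0-fold lower number from compound 3 to compound 4 (0.02 log units; that floor lies within the scatter). Compound 4 is therefore estimated at 190000 nM, most likely between 110000 nM and 320000 nM, with a fair chance that only a limit is reported again.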

Compound 4, half-maximal inhibitory concentration: 40000 nM
Compound 4: the middle estimate sits 4.8-fold (0.68 log units) above what was measured, and the stated range ends above it.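

Moving from methyl to bromo on the core of compound 3 gave, in this assay, an at least 5.0-fold lower number from compound 3 to compound 4 (0.69 log units; beyond the scatter). This does not show that the change acts differently on the two cores, nor that it carries over with a fixed size, since the two steps cannot be compared directly: the same change on two cores in this assay, an at least 1.1-fold lower number (0.07 log units; that floor lies within the scatter) from compound 1 to compound 2 and an at least 5.0-fold lower number (0.69 log units; beyond the scatter) from compound 3 to compound 4; the limit leaves it open whether they differ The true size of each step also stays hidden, and only its floor can be read: the limit of > 200000 nM in this assay, at which 2 of the 4 values shown sit.

The compounds shown carry only methyl or bromo at this place, so it remains open whether a chloro, methoxy or trifluoromethyl group there would give a number like that of the bromo compounds or stay at the limit. As far as these compounds go, whether the step would repeat on any core beyond these two also remains open.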